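Taking the Phenyl off the Phenoxy Oxygen

The source may report more compounds than this note shows. Statements on the series, on what has been measured and on what is new or still open speak of the compounds shown alone.

Compound 3 `Cc1cc(Nc2cc(Cl)c(Oc3ccccc3)c(Cl)c2)nc(N)n1` stands, in an assay on cells for inhibition of S-adenosylmethionine decarboxylase proenzyme (Homo sapiens), read by mass spectrometry, at pH 7.2 (on this read-out higher numbers stand for weaker inhibition and lower numbers for stronger inhibition), at a limit of the assay rather than at a number, > 180000 nM. Compound 1 `Cc1cc(Nc2cc(Cl)c(Cl)c(Cl)c2)nc(N)n1` also gives only a limit in this assay, namely > 63000 nM. Compound 2 `Cc1cc(Nc2cc(Cl)c(C)c(Cl)c2)nc(N)n1` likewise stops at a limit in this assay, > 63000 nM. Compound 4 `Cc1cc(Nc2cc(Cl)c(O)c(Cl)c2)nc(N)n1` has not been measured; it differs from compound 3 by hydrogen in place of phenyl on an oxygen on an aromatic ring. The measured steps that touch the same part of the molecule are a step that the two limits leave unreadable from compound 1 to compound 3 and a step that the two limits leave unreadable from compound 2 to compound 3, with a step that the two limits leave unreadable from compound 1 to compound 2 alongside them. None of the three has a readable size, all of their endpoints resting at the limit of > 63000 nM in this assay, at which 2 of the 3 values shown sit, or at the limit of > 180000 nM in this assay, at which 1 of the 3 values shown sits. The expectation for compound 4 therefore rests on limits alone, and a step of an at least 1.8-fold lower number from compound 3 to compound 4 (0.25 log units; that floor lies within the scatter) is expected, with compound 4 most likely reported again as a limit. Compound 4 is estimated at 100000 nM, with a range from 30000 nM to 300000 nM.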

Compound 4, half-maximal inhibitory concentration: > 180000 nM
Compound 4 ended at the assay's limit (the forecaster's own chance of this, stated with the estimate: 80%); at least 1.8-fold (0.25 log units) between middle value and limit.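

In this assay compound 4 gives only a limit, > 180000 nM. Among these compounds, with all four values at limits, no step from compound 1, compound 2 or compound 3 to compound 4 can be read. The compounds shown leave open how chloro, methyl, phenoxy and hydroxy truly compare at that place.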